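A ring exchange from compound 3 to compound 4

The source may hold more compounds than are shown below. What is called first, only, known or untested is meant among the compounds shown, and "the series" means these compounds.

Compound 1 (`Cc1ccncc1-c1ccc2[nH]c(=O)nc(-c3ccccc3)c2c1`), compound 2 (`O=c1nc(-c2ccccc2)c2cc(-c3ccccc3)ccc2[nH]1`) and compound 3 (`O=c1nc(-c2ccccc2)c2cc(-c3cccc(F)c3)ccc2[nH]1`) share one core and differ in a single group on an aromatic carbon. In an ADME assay on THP-1 cells (Homo sapiens) for cytotoxicity, read by MTT assay, with a stated time of 72 h (a higher number here means that more compound is needed for the effect, a lower number that less compound is needed), compound 1 reads > 50000 nM as a limit. Compound 2 reads > 50000 nM as a limit too. Going by the values given here, compound 3 reads > 50000 nM as a limit as well, the same place as every compound measured so far (the limit of > 50000 nM in this assay, at which 3 of the 3 values shown sit).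

Compound 4 (`Cn1nccc1-c1ccc2[nH]c(=O)nc(-c3ccccc3)c2c1`) carries 1-methyl-1H-pyrazol-5-yl in place of 3-fluorophenyl on an aromatic carbon. Among the compounds with values here, three measured steps bear on this: a step that the two limits leave unreadable from compound 1 to compound 2 and a step that the two limits leave unreadable from compound 1 to compound 3 at the same carbon, and a step that the two limits leave unreadable from compound 2 to compound 3 for the fluoro group. Within the data shown here, none has a readable size, so they show only that all three groups end at the same limit. No step beyond the scatter is therefore expected in this assay and another limit is the likely report. The expected step is small (a number no higher from compound 3 to compound 4 (the limit leaves the size open)). Expected for compound 4 is 50000 nM within a range of 25000 nM to 100000 nM as the estimated span.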

Compound 4, half-maximal effective concentration: > 50000 nM
Compound 4: a limit, no number; the forecaster's own chance of this, stated with the estimate: 90%; the middle value lies on the limit itself.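

Compound 4 joins compound 1, compound 2 and compound 3 at the same limit, so no step among these compounds can be read: the limit of > 50000 nM in this assay, at which 4 of the 4 values shown sit.
The compounds shown leave open where each true value lies beyond that limit, and whether any group on this aromatic carbon would give a readable number in this assay at all.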